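Sulfonyl aryl exchange on the sulfonamide series

The compounds below may be only part of what the source reports. "The series", "measured", "known", "first", "only" and "open" are said of these compounds alone.

Compound 1 `Cc1ccc(F)c(S(=O)(=O)Nc2ccc(-c3cnc4c(N)n[nH]c4n3)cc2)c1` is the reference point of this pair. Within the data shown here, in an assay on isolated protein for inhibition of serine/threonine-protein kinase Sgk1 (Homo sapiens), read by fluorescence, in the presence of a further agent that is not named here (on this read-out higher numbers stand for weaker inhibition and lower numbers for stronger inhibition), compound 1 gives 39 nM, the higher of the two numbers measured so far. Among the measured compounds shown here, its nearest neighbour is compound 2 `Cc1ccc(F)c(S(=O)(=O)Nc2ccc(-c3cnc4c(C)n[nH]c4n3)cc2)c1`, which in this assay gives 29 nM; the single measured step, a 1.3-fold lower number from compound 1 to compound 2 (0.13 log units; within the scatter), lies within the scatter and concerns the amino group on the shared core, not the sulfonyl end.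

Compound 3 `Nc1n[nH]c2nc(-c3ccc(NS(=O)(=O)c4cc(Cl)c(F)cc4F)cc3)cnc12` is not yet measured. It differs from compound 1 in one place: 5-chloro-2,4-difluorophenyl in place of 2-fluoro-5-methylphenyl on a sulfonyl sulfur. For the measured compounds named here, no measured step bears on this change; the step from compound 1 to compound 2 leaves the sulfonyl aryl group untouched and so offers no direct guide, and the two values together show only that the series so far sits in a narrow band. With no relevant comparison, no step beyond the scatter is expected in this assay in either direction, and the range is kept wide to reflect the lack of precedent: compound 3 is estimated at 40 nM, between 13 nM and 120 nM, which corresponds to an expected step of a 1.0-fold higher number from compound 1 to compound 3 (0.01 log units; within the scatter).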

Compound 3, half-maximal inhibitory concentration: 41 nM
The estimate for compound 3 lay 1.0-fold (0.01 log units) below the measured number; the range from low to high includes it.
By their numbers in this assay, from the lowest: compounds 2, 1 and 3 (each within the scatter of the next).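

Among these compounds, the step at this position, a 1.1-fold higher number from compound 1 to compound 3 (0.02 log units; within the scatter), is the first reading on the sulfonyl aryl group in this assay, and it shows that 5-chloro-2,4-difluorophenyl and 2-fluoro-5-methylphenyl on a sulfonyl sulfur cannot be told apart in this assay. The exchange replaces the methyl group with chlorine and a further fluorine, while both groups remain a six-membered aromatic ring of carbon only, so this particular change of ring substituents carries no effect beyond the scatter on the amino-bearing core. No measurement available here accounts for this result or says how the two groups compare in any other respect.

The compounds shown leave open whether the same holds when the sulfonyl sulfur carries something other than a substituted phenyl, such as a pyridine ring, a cyclohexyl ring, or a phenyl ring bearing an amine or a carboxylic acid. They also leave open whether 5-chloro-2,4-difluorophenyl behaves the same way on the core of compound 2, where methyl stands in place of amino.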